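Furan in Place of Dimethoxyphenyl on a Shared Core

The compounds below may be only part of what the source reports. "The series", "measured", "known", "first", "only" and "open" are said of these compounds alone.

Compound 1 `COc1ccc(-c2c(C)nc3c(N4CC[C@@H](NC(C)=O)C4)cc(C)nn23)cc1OC`: > 95%
Compound 2 `COc1ccc(-c2c(C)sc3c(N4CC[C@@H](NC(C)=O)C4)nc(C)nc23)cc1OC`: > 95%
Compound 3 `CSc1ccc(-c2c(C)nc3c(N4CC[C@@H](NC(C)=O)C4)cc(C)nn23)cc1`: > 95%

In an ADME assay on microsomes from liver (Homo sapiens) for metabolic stability, read by LC-MS, with NADPH named in the record, with a stated time of 60 min, tested at 1 uM, in the absence of a further agent (on this read-out higher numbers stand for a more stable compound and lower numbers for a less stable compound), compound 1 gives > 95%, which is a limit of the assay rather than a number. Compound 2 and compound 3 also stand at that limit, so that (the limit of > 95% in this assay, at which 3 of the 3 values shown sit). Among the measured compounds shown here, the one comparable change, a step that the two limits leave unreadable from compound 1 to compound 3, therefore cannot be read, and nothing measured here tells the size of the step to compound 4 `CC(=O)N[C@@H]1CCN(c2cc(C)nn3c(-c4ccco4)c(C)nc23)C1`. The change itself is furan-2-yl in place of 3,4-dimethoxyphenyl on an aromatic carbon. For the measured compounds named here, with the only related step unreadable, no direction can be drawn from the data. For compound 4 the expected value in this assay is 85%, from 55% to 97%. The step of a number at least 10 percentage points lower from compound 1 to compound 4 (that floor lies within the scatter) is thus estimated with wide uncertainty.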

Compound 4, percent of the compound remaining: > 95%
Compound 4: only a limit was reported (the forecaster's own chance of this, stated with the estimate: 45%); at least 10 percentage points between middle value and limit.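

The steps from compound 1 and compound 3 to compound 4 cannot be read, as all of these compounds stand at a limit of the assay: the limit of > 95% in this assay, at which 4 of the 4 values shown sit.

The compounds shown leave open whether furan-2-yl, 3,4-dimethoxyphenyl and 4-(methylsulfanyl)phenyl differ at all in this assay.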